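A few compounds are considered here, and "the series" means these few. Any claim that something is new, unique, unknown or untested is made for them only; others in the source may bear on it.

Compound 2, with the structure `Fc1ccc(-c2nc3cc(C(F)(F)F)ccc3[nH]2)cc1`, gives the highest of the two numbers recorded in an ADME assay on BHK cells (Mesocricetus auratus) for cytotoxicity, read by MTT assay, with a stated time of 96 h; a higher number here means that more compound is tolerated, a lower number that less compound is tolerated: compound 2 gives 25000 nM. Its nearest neighbour on this scale is compound 1, `O=C(CN1CCCCC1)Nc1ccc(-c2nc3cc(C(F)(F)F)ccc3[nH]2)cc1`, which in this assay gives 12000 nM, a lower number that lies beyond the scatter of repeated measurements. The unmeasured compound 3, `O=C(CN1CCCC1)Nc1ccc(-c2nc3cc(C(F)(F)F)ccc3[nH]2)cc1`, differs from compound 2 in one place: (((pyrrolidin-1-yl)methyl)carbonyl)amino in place of fluoro on an aromatic carbon. Within the data shown here, no pair of measured compounds separated by exactly this change is available, so the expectation rests on compound 1 alone. Because compound 1, carrying a closely related group at the same place, gives 12000 nM, compound 3 is expected to sit near that level rather than at the level of compound 2. The step of a 1.9-fold lower number from compound 2 to compound 3 (0.28 log units; within the scatter) is therefore expected to be a modest decrease, somewhat beyond the scatter. For compound 3 the estimate in this assay is 13000 nM, with a likely range from 6000 nM to 28000 nM.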

Compound 3, half-maximal cytotoxic concentration: 29000 nM
For compound 3 the middle estimate is 2.2-fold (0.35 log units) below the measured one; the measured number lies above the stated range.
By their numbers in this assay, from the lowest: compound 1; then compounds 2 and 3 (each within the scatter of the next).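

In this assay, (((pyrrolidin-1-yl)methyl)carbonyl)amino in place of fluoro on an aromatic carbon gives a 1.2-fold higher number from compound 2 to compound 3 (0.06 log units; within the scatter) and thus shows that this far larger group can stand at this place with no step beyond the scatter. Among these compounds, on the saturated chain carbon bound to the carbonyl carbon, pyrrolidin-1-yl in place of piperidin-1-yl gives a 2.4-fold higher number from compound 1 to compound 3 (0.38 log units; beyond the scatter) and so shows that the ring at the end of this group matters here, which the earlier compounds could not show. Nothing available explains this difference between the two rings.

The compounds shown leave open whether a morpholine ring or an open-chain dimethylamine at the end of this group would stay with the pyrrolidine or with the piperidine. They also leave open how a longer chain between the carbonyl and the ring would read in this assay.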